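A fluoro step in a level series

The compounds below may be only part of what the source reports. "The series", "measured", "known", "first", "only" and "open" are said of these compounds alone.

Compound 1 `COc1c(N2C[C@H]3CCCN(C(=O)Cn4cc(CN5C(=O)/C(=N/O)c6cccc(F)c65)nn4)[C@H]3C2)c(F)cc2c(=O)c(C(=O)O)cn(C3CC3)c12` gives 16 ug/mL 
Compound 2 `CO/N=C1/C(=O)N(Cc2cn(CC(=O)N3CCC[C@@H]4CN(c5c(F)cc6c(=O)c(C(=O)O)cn(C7CC7)c6c5OC)C[C@@H]43)nn2)c2c(F)cccc21` gives 16 ug/mL 
Compound 3 `COc1c(N2C[C@H]3CCCN(C(=O)Cn4cc(CN5C(=O)/C(=N/NC(N)=S)c6ccccc65)nn4)[C@H]3C2)c(F)cc2c(=O)c(C(=O)O)cn(C3CC3)c12` gives 16 ug/mL 

In an ADME assay on Vero cells (Chlorocebus sabaeus) for cytotoxicity, read by MTT assay, with a stated time of 72 h (a higher number here means that more compound is tolerated, a lower number that less compound is tolerated), compound 3 gives 16 ug/mL and so stands level with compound 1 and compound 2, with nothing separating the three. The next structure is compound 4 `COc1c(N2C[C@H]3CCCN(C(=O)Cn4cc(CN5C(=O)/C(=N/NC(N)=S)c6cccc(F)c65)nn4)[C@H]3C2)c(F)cc2c(=O)c(C(=O)O)cn(C3CC3)c12` and it departs from compound 3 in one place only, with fluoro in place of hydrogen on an aromatic carbon and the remainder of the structure untouched.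

Among the compounds with values here, no measured step makes this same exchange. Within the data shown here, the one single-place step available is methyl in place of hydrogen on an oxygen, a different kind of change, and it shows no change at the digits printed from compound 1 to compound 2 (within the scatter) in this series. Among the measured compounds shown here, that step and the three level values are the only guide, and they give no sign of direction. No step beyond the scatter is therefore expected in this assay for the new fluoro. The estimated step is no change at the digits printed from compound 3 to compound 4 (within the scatter) on this evidence. Level values say little about what one untested exchange can do, so the range is kept open on both sides. Compound 4 is estimated at 16 ug/mL with an expected range from 8 ug/mL to 32 ug/mL when it is measured.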

Compound 4, half-maximal cytotoxic concentration: 8 ug/mL
Compound 4: middle estimate off by 2.0-fold (0.30 log units), on the high side; the measured number falls inside the stated range.
By their numbers in this assay, from the lowest: compounds 4, 1, 2 and 3 (each within the scatter of the next).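

In this assay, within the data shown here, the exchange of fluoro for hydrogen on an aromatic carbon, ortho to a fused ring and meta to a fused ring, gives a 2.0-fold lower number from compound 3 to compound 4 (0.30 log units; within the scatter) and so adds a first reading at this position, one that stays inside the scatter. With that fluoro in place on both sides, the group of 4 heavy atoms on the double-bonded nitrogen gives a 2.0-fold lower number from compound 1 to compound 4 (0.30 log units; within the scatter) where it replaces one oxygen atom and a 2.0-fold lower number from compound 2 to compound 4 (0.30 log units; within the scatter) where it replaces the group of 2 heavy atoms, so neither exchange at that nitrogen separates these compounds in this assay. Nothing measured here bears on the reason for these readings.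

On these data alone, the fluoro exchange is seen on one pair only, so how it reads with the oxygen-bearing groups of compound 1 and compound 2 on the double-bonded nitrogen stays open. Whether a chlorine, a methoxy group or an amine on the same aromatic carbon would also stay within the scatter is equally open, as the compounds shown carry only hydrogen or fluoro there.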